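Compound 2 to compound 3: sulfonyl on ring nitrogen

The source may report more compounds than this note shows. Statements on the series, on what has been measured and on what is new or still open speak of the compounds shown alone.

Of the compounds shown here, two have values so far in a functional assay on GOTO cells (Homo sapiens) for cytotoxicity, read by MTT assay, with a stated time of 3 days; a higher number here means a weaker inhibitor, a lower number a stronger inhibitor. Compound 1 `N#Cc1c(Nc2ccccn2)nc(SCc2nc3ccccc3[nH]2)nc1-c1ccccc1` gives 2.5 nM. Compound 2 `N#Cc1c(-c2ccccc2)nc(SCc2nc3ccccc3[nH]2)nc1N1CCNCC1` gives 3.7 nM, which places compound 2 level with compound 1 within the scatter.

Compound 3 `Cc1ccc(S(=O)(=O)N2CCN(c3nc(SCc4nc5ccccc5[nH]4)nc(-c4ccccc4)c3C#N)CC2)cc1` keeps the core of compound 2 and takes (4-methylphenyl)sulfonyl in place of hydrogen on an amine nitrogen in a ring.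

Among the measured compounds shown here, only one measured step bears on this change: a 1.5-fold higher number from compound 1 to compound 2 (0.17 log units; within the scatter), with piperazin-1-yl in place of (pyridin-2-yl)amino on an aromatic carbon. That step lies within the scatter, but it introduces the ring that compound 3 substitutes and does not test substitution on that ring. For the measured compounds named here, no measured compound carries a sulfonyl group, so the evidence is thin. A small rise in the number is expected, probably not beyond the scatter, and the direction is held only weakly. The expected step is a 1.6-fold higher number from compound 2 to compound 3 (0.21 log units; within the scatter). Compound 3 is estimated at 6 nM, with an expected range of 1.5 nM to 30 nM.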

Compound 3, half-maximal inhibitory concentration: 4.38 nM
Compound 3: middle estimate off by 1.4-fold (0.14 log units), on the high side; measured number inside the range.
By their numbers in this assay, from the lowest: compounds 1, 2 and 3 (each within the scatter of the next).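

In this assay the new step gives a 1.2-fold higher number from compound 2 to compound 3 (0.07 log units; within the scatter) and so lies within the scatter, even though (4-methylphenyl)sulfonyl brings 10 heavy atoms and an aromatic ring to a site that carried only hydrogen. Among the compounds shown here, the earlier step exchanged the whole group on the aromatic carbon, whereas this one is the first test of substitution on the amine nitrogen of the six-membered non-aromatic ring, and it shows that, for this pair, the hydrogen on that nitrogen is not needed to keep the number level with compound 2. No measurement on these compounds accounts for this tolerance.

As far as these compounds go, the result rests on one substituent at one nitrogen, so it remains open whether a simple methyl, an acetyl amide or a chain ending in a carboxylic acid would also leave the number level. Methylsulfonyl or unsubstituted phenylsulfonyl at the same nitrogen would show whether the sulfonyl link or the 4-methylphenyl ring matters to this tolerance, and the shared core's phenyl and nitrile groups remain untested by any step in this set.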